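Does losing the 2-benzoylethenyl group reveal cytotoxicity?

A few compounds are considered here, and "the series" means these few. Any claim that something is new, unique, unknown or untested is made for them only; others in the source may bear on it.

Compound 1 `COc1ccc(/C=C/[C@@](C)(/C=C/c2ccc(O)c(/C=C/C(=O)OC(C)(C)C)c2)CCC=C(C)C)cc1`: > 36600 nM
Compound 2 `COc1ccc(/C=C/[C@@](C)(/C=C/c2ccc(O)c(/C=C/C(=O)c3ccccc3)c2)CCC=C(C)C)cc1`: > 36600 nM

In an ADME assay on HEK293 cells (Homo sapiens) for cytotoxicity, with a stated time of 72 h (a lower number here means that less compound is needed, a higher number that more compound is needed for the effect), compound 2 gives > 36600 nM, which is a limit and not a number. Compound 1 gives > 36600 nM, which is also a limit. Both compounds therefore share one ceiling: the limit of > 36600 nM in this assay, at which 2 of the 2 values shown sit. Among the compounds with values here, the only measured step is a step that the two limits leave unreadable from compound 1 to compound 2, so it offers no size to carry forward.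

Compound 3 `COc1ccc(/C=C/[C@@](C)(/C=C/c2ccc(O)cc2)CCC=C(C)C)cc1` differs from compound 2 at one place: hydrogen in place of 2-benzoylethenyl on an aromatic carbon. Within the data shown here, no measured step covers the loss of this group, so the data give only weak guidance. The expectation rests on compound 2 at > 36600 nM, a limit, and no clear change in either direction is expected. The estimated step is a step that the limit leaves unreadable from compound 2 to compound 3, and it is expected to stay small. Compound 3 is estimated at 40000 nM, with an expected range from 15000 nM to 80000 nM.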

Compound 3, half-maximal effective concentration: > 36600 nM
Compound 3 ended at the assay's limit (the forecaster's own chance of this, stated with the estimate: 80%); the middle value lies beyond the limit too.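

Compound 1, compound 2 and compound 3 all give a limit and not a number, so no step among them can be read: the limit of > 36600 nM in this assay, at which 3 of the 3 values shown sit.

From the compounds shown here alone, how far these compounds truly differ in this assay, and whether the 2-benzoylethenyl group matters there, stays open.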